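Swapping the Benzyl Substituent on an Indole Nitrogen

A few compounds are considered here, and "the series" means these few. Any claim that something is new, unique, unknown or untested is made for them only; others in the source may bear on it.

Measured compounds:
- compound 1, `CCCCCCn1ccc2cc(/C(C)=C/C(=O)Nc3ccccc3OCCCC(=O)O)ccc21`, 77 nM
- compound 2, `C/C(=C\C(=O)Nc1ccccc1OCCCC(=O)O)c1ccc2c(ccn2CC(C)C)c1`, 160 nM
- compound 3, `C/C(=C\C(=O)Nc1ccccc1OCCCC(=O)O)c1ccc2c(ccn2Cc2ccccc2C)c1`, 69 nM

All three share one core and differ only in the group on the saturated chain carbon bound to the aromatic nitrogen. In an assay on Prostate gland for inhibition of steroid 5-alpha-reductase (Rattus norvegicus) (on this read-out lower numbers stand for stronger inhibition and higher numbers for weaker inhibition), compound 3 sits at the strong end of this small set: it is separated from compound 2 by a 2.3-fold lower number from compound 2 to compound 3 (0.37 log units; beyond the scatter), but from compound 1 only by a 1.1-fold lower number from compound 1 to compound 3 (0.05 log units; within the scatter), so compound 1 and compound 3 cannot be told apart on these numbers.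

Compound 4, `C/C(=C\C(=O)Nc1ccccc1OCCCC(=O)O)c1ccc2c(ccn2Cc2ccc(C(C)(C)C)cc2)c1`, has not yet been measured. It differs from compound 3 in one place: 4-(tert-butyl)phenyl in place of 2-methylphenyl on a saturated chain carbon bound to an aromatic nitrogen. Going by the values given here, no measured step changes a substituent on that phenyl ring, so none bears on this change directly. The nearest guidance is that a larger group gave a 2.1-fold higher number from compound 1 to compound 2 (0.32 log units; beyond the scatter) in reverse and a 1.1-fold lower number from compound 1 to compound 3 (0.05 log units; within the scatter), both small. For compound 4 a step of a 1.0-fold higher number from compound 3 to compound 4 (0.01 log units; within the scatter) in this assay is therefore expected, essentially none beyond the scatter. Compound 4 is estimated at 70 nM, with a range from 30 nM to 170 nM.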

Compound 4, half-maximal inhibitory concentration: 170 nM
The estimate for compound 4 lay 2.4-fold (0.39 log units) below the measured number, and the stated range covers the measured number.
By their numbers in this assay, from the lowest: compounds 3 and 1 (each within the scatter of the next); then compounds 2 and 4 (each within the scatter of the next).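

In this assay, keeping the phenyl ring does not keep the number: 4-(tert-butyl)phenyl in place of 2-methylphenyl gives a 2.5-fold higher number from compound 3 to compound 4 (0.39 log units; beyond the scatter), so what the ring carries matters at this position. The same group gives a 2.2-fold higher number from compound 1 to compound 4 (0.34 log units; beyond the scatter) in place of pentyl but only a 1.1-fold higher number from compound 2 to compound 4 (0.03 log units; within the scatter) in place of isopropyl, so a phenyl ring on this chain carbon does not by itself give a number at the low end of the set. Nothing measured here explains this shift.

It remains open whether the shift follows from adding the tert-butyl group or from losing the methyl, since no compound shown has a plain phenyl here. Going by these compounds, how a phenyl ring carrying an amine or a carboxylic acid would read in this assay also stays open.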